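Moving the hydroxyl on a naphthyloxyacetohydrazone series

The source may report more compounds than this note shows. Statements on the series, on what has been measured and on what is new or still open speak of the compounds shown alone.

Three hydrazones sharing one core have been tested in an ADME assay on HEL cells (Homo sapiens) for cytotoxicity; on this read-out higher numbers stand for lower toxicity in this test and lower numbers for higher toxicity in this test. Compound 1 `COc1cc(/C=N/NC(=O)COc2cccc3ccccc23)cc(OC)c1OC` carries a trimethoxyphenyl group, and in this assay compound 1 reaches only a limit of the assay, >= 20 ug/mL. Compound 2 `O=C(COc1cccc2ccccc12)N/N=C/c1c(O)ccc2ccccc12`, with a hydroxynaphthyl group, gives in this assay a value of 4 ug/mL. Compound 3 `O=C(COc1cccc2ccccc12)N/N=C/c1ccc(O)cc1`, bearing a 4-hydroxyphenyl group, gives in this assay a value of 20 ug/mL.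

Among the two numbers, compound 3 stands highest; its nearest neighbour is compound 2, whose number is lower by a margin that lies beyond the usual scatter. The third value, that of compound 1, is a limit and not a number, as the record shows: the limit of >= 20 ug/mL in this assay, at which 1 of the 3 values shown sits.

Compound 4 `O=C(COc1cccc2ccccc12)N/N=C/c1ccccc1O` has not yet been measured in this assay. It differs from compound 3 by 2-hydroxyphenyl in place of 4-hydroxyphenyl on a carbon with a double bond to nitrogen. Among the compounds with values here, since no measured pair shows this change, the expected step is uncertain; a step from compound 3 to compound 4 of a 1.3-fold lower number from compound 3 to compound 4 (0.10 log units; within the scatter) is expected, staying within the scatter. Compound 4 is therefore estimated to give 16 ug/mL in this assay, within a range from 5 ug/mL to 40 ug/mL.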

Compound 4, minimum cytotoxic concentration: 20 ug/mL
The estimate for compound 4 lay 1.3-fold (0.10 log units) below the measured number; the measured number falls inside the stated range.
By their numbers in this assay, from the lowest: compound 2; then compounds 3 and 4 (each within the scatter of the next).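

Within the data shown here, the swap of 4-hydroxyphenyl for 2-hydroxyphenyl on a carbon with a double bond to nitrogen gives the first step that can be read in this assay: no change at the digits printed from compound 3 to compound 4 (within the scatter). Among these compounds, at this place, then, the read-out does not tell apart two hydroxyphenyl groups that have the same atoms, joined differently, a point the earlier compounds could not show, as none of them formed a pair differing in one place. Compound 1 remains a limit of the assay and not a number: the limit of >= 20 ug/mL in this assay, at which 1 of the 4 values shown sits.

What an aminophenyl or a carboxyphenyl group would give on this same carbon stays open, as does whether 3-hydroxyphenyl would fit with the two hydroxyphenyl groups shown here. In this assay compound 2 gives 4 ug/mL, and this single value leaves open which part of its hydroxynaphthyl group goes with that number, since no compound shown separates the hydroxyl from the second ring.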